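Proline sulfonamide series: aryl in place of isopropyl

This account rests on a few compounds, and the source may have more. Where it says the series, first, only, none or still open, it means among the compounds named here.

Going by the values given here, compound 1 `CC(C)[C@@H](CC(=O)O)NC(=O)[C@@H]1CCCN1S(=O)(=O)c1cc(Cl)cc(Cl)c1` is the single number given in an assay on RPMI-8866 cells for inhibition of integrin alpha-4/beta-1 (Homo sapiens) (a lower number here means a stronger inhibitor, a higher number a weaker inhibitor), where compound 1 gives 8.9 nM. Compound 2 `COc1ccc([C@@H](CC(=O)O)NC(=O)[C@@H]2CCN2S(=O)(=O)c2cc(Cl)cc(Cl)c2)cc1`, which carries a 4-methoxyphenyl on the same chain carbon and a smaller ring in its core, has several entries rather than one number; in this assay compound 2 gives 0.39 nM; 0.49 nM (2 entries), the lower figures of the two measured compounds. The unmeasured compound 3 `O=C(O)C[C@@H](NC(=O)[C@@H]1CCCN1S(=O)(=O)c1cc(Cl)cc(Cl)c1)c1ccc(OC(F)(F)F)cc1` keeps the core of compound 1 and differs from it in one place: 4-(trifluoromethoxy)phenyl in place of isopropyl on a saturated chain carbon bound to an amide-type nitrogen and a saturated chain carbon. Among the compounds with values here, no measured pair shows this change directly, so the size of the step is not known from the data. Compound 3 is expected to be the stronger inhibitor, with a step from compound 1 of a 5.9-fold lower number from compound 1 to compound 3 (0.77 log units; beyond the scatter) beyond the scatter, the expectation resting on compound 2, whose aryl-bearing entries the several entries of compound 2 in this assay, 0.39 nM; 0.49 nM (2 entries) sit well below compound 1. For compound 3 the estimate in this assay is 1.5 nM, within 0.4 nM to 6 nM.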

Compound 3, half-maximal inhibitory concentration: 2.6 nM
Beside the measured number, compound 3's estimate is 1.7-fold (0.24 log units) below it; the measured number falls inside the stated range.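

In this assay, the saturated chain carbon bound to an amide-type nitrogen and a saturated chain carbon accepts a far larger group, one carrying an aromatic ring: 4-(trifluoromethoxy)phenyl in place of isopropyl gives a 3.4-fold lower number from compound 1 to compound 3 (0.53 log units; beyond the scatter). Going by these compounds alone, this is the first reading of this change on its own, with the core held fixed, and it shows that the aryl group alone is enough for a modest gain. Compound 2 pointed the same way, but it differs from compound 1 in more than one place, so its figures could not isolate this change: the several entries of compound 2 in this assay, 0.39 nM; 0.49 nM (2 entries)

Going by these compounds, whether the gain comes from the aromatic ring itself or from its trifluoromethoxy group remains open, and a plain phenyl group at this place would separate the two. Also open, on these data alone, is how much of the low figures of compound 2 comes from the smaller ring in its core rather than from its aryl group.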